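Benzoyl in Place of a Sulfonyl Group on the Amine Nitrogen

A few compounds are considered here, and "the series" means these few. Any claim that something is new, unique, unknown or untested is made for them only; others in the source may bear on it.

Compound 1 `O=S(=O)(NCCCNc1nccc(-c2c(-c3cccc(F)c3)nc3sccn23)n1)c1ccc(C(F)(F)F)cc1`: 11700 nM
Compound 2 `O=S(=O)(NCCNc1nccc(-c2c(-c3cccc(F)c3)nc3sccn23)n1)c1ccc(Cl)cc1`: 18600 nM
Compound 3 `O=S(=O)(NCCNc1nccc(-c2c(-c3cccc(F)c3)nc3sccn23)n1)c1ccc(C(F)(F)F)cc1`: 8450 nM

Of the compounds shown here, three sharing one core have been measured in a functional assay on SK-MEL-28 cells (Homo sapiens) for cytotoxicity, read by MTT assay; on this read-out higher numbers stand for weaker inhibition and lower numbers for stronger inhibition. Compound 2 gives the highest of the three numbers. Its nearest neighbour is compound 1, whose value lies within the scatter of that of compound 2, so no order can be read between them. For the measured compounds named here, compound 3 stands furthest away, and the one step recorded between single-point changes is a 2.2-fold lower number from compound 2 to compound 3 (0.34 log units; beyond the scatter), a change made on the ring of the sulfonyl group.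

Compound 4 `O=C(NCCNc1nccc(-c2c(-c3cccc(F)c3)nc3sccn23)n1)c1ccccc1` has not yet been measured. It differs from compound 2 in one place: benzoyl in place of (4-chlorophenyl)sulfonyl on an amine nitrogen. Going by the values given here, the change therefore touches the group that carries the whole of the sulfonyl part, and no measured pair tells how this core responds to a benzamido group. The step from compound 2 to compound 3, being a change on the ring alone, bears on it only loosely. Given this, a step of no more than the usual scatter is expected, and the number for compound 4 is estimated at 17000 nM, within 6000 nM to 50000 nM, with the expected step being a 1.1-fold lower number from compound 2 to compound 4 (0.04 log units; within the scatter).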

Compound 4, half-maximal inhibitory concentration: 17000 nM
Compound 4: the middle estimate sits on the measured number at the digits printed, within the range that was stated.
By their numbers in this assay, from the lowest: compounds 3, 1, 4 and 2 (each within the scatter of the next, the first and the last beyond it).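

In this assay, putting benzoyl in place of (4-chlorophenyl)sulfonyl on the amine nitrogen gives a 1.1-fold lower number from compound 2 to compound 4 (0.04 log units; within the scatter), so no difference can be read between the two compounds. The earlier step, a 2.2-fold lower number from compound 2 to compound 3 (0.34 log units; beyond the scatter), changed only the substituent on the aromatic ring and left the sulfonyl group in place, whereas this result shows that the whole group can be exchanged for a benzoyl group, with its carbonyl and unsubstituted ring, without a readable shift in the number for compound 4. No measurement of any other kind is available to account for this lack of a readable shift in the cell read-out, and the numbers alone offer no explanation.

The exchange removes the sulfonyl link and the chlorine in one step, so the two changes cannot be separated here, and a 4-chlorobenzoyl or 4-(trifluoromethyl)benzoyl group on the same nitrogen would be needed to show whether the ring step seen with the sulfonyl group carries over to the benzamido series. As far as these compounds go, how far this position stretches also stays open, since a free primary amine or a small acetyl group on that nitrogen, with no aromatic ring at all, would test whether the ring matters to the number.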